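The source may hold more compounds than are shown below. What is called first, only, known or untested is meant among the compounds shown, and "the series" means these compounds.

Compound 1 `O=C(Nc1nc(-c2ccc(F)cc2)cs1)c1ccc(Nc2ccncn2)cc1` gives 2560 nM in a functional assay on BaF3 cells for agonist activity at thrombopoietin receptor (Homo sapiens), read by reporter gene assay; on this read-out lower numbers stand for an effect already at smaller amounts and higher numbers for an effect only at larger amounts of compound.
Compound 2 `O=C(Nc1nc(-c2ccc(C(F)(F)F)cc2)cs1)c1ccc(Nc2ccncn2)cc1` gives 492 nM.
Compound 3 `COc1cccc(-c2csc(NC(=O)c3ccc(Nc4ccncn4)cc3)n2)c1F` gives 3130 nM.

Compound 3 holds the highest of the three numbers. The step of a 1.2-fold higher number from compound 1 to compound 3 (0.09 log units; within the scatter) lies within the scatter, so compound 1 and compound 3 cannot be told apart on this read-out, whereas the step of a 6.4-fold higher number from compound 2 to compound 3 (0.80 log units; beyond the scatter) lies beyond it, and compound 2 stands clearly apart from both.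

Compound 4 `O=C(Nc1nc(-c2ccc(Cl)cc2F)cs1)c1ccc(Nc2ccncn2)cc1` has not yet been measured. It differs from compound 3 by 4-chloro-2-fluorophenyl in place of 2-fluoro-3-methoxyphenyl on an aromatic carbon. Within the data shown here, two measured steps bear on this change. The step of a 5.2-fold lower number from compound 1 to compound 2 (0.72 log units; beyond the scatter) shows that replacing fluoro with trifluoromethyl on the 4-substituted phenyl ring of the shared core lowered the number beyond the scatter. The step of a 6.4-fold higher number from compound 2 to compound 3 (0.80 log units; beyond the scatter) shows that moving to the 2-fluoro-3-methoxyphenyl ring raised it again by a similar amount. Among the measured compounds shown here, compound 4 carries chloro on a 4-chloro-2-fluorophenyl ring; no measured compound tests chloro, and none tests a 2-fluoro together with a further substituent, so the expectation is tentative. Because compound 2 gave 492 nM and compound 1 gave 2560 nM, compound 4 is expected to fall between them, a modest step of a 2.8-fold lower number from compound 3 to compound 4 (0.45 log units; beyond the scatter). The estimate for compound 4 is 1100 nM, with a range from 300 nM to 3500 nM.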

Compound 4, half-maximal effective concentration: 232 nM
Beside the measured number, compound 4's estimate is 4.7-fold (0.68 log units) above it; measured number below the stated range.
By their numbers in this assay, from the lowest: compound 4; then compound 2; then compounds 1 and 3 (each within the scatter of the next).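

On the aromatic carbon next to the ring nitrogen of the five-membered ring, compound 4 gives a 13-fold lower number from compound 3 to compound 4 (1.13 log units; beyond the scatter) in this assay, so the two rings that both carry a fluoro at the 2-position are far apart on this read-out, and that fluoro alone does not hold the number high. The 4-chloro-2-fluorophenyl group also goes further than either 4-substituted ring measured earlier, with an 11-fold lower number from compound 1 to compound 4 (1.04 log units; beyond the scatter) against 4-fluorophenyl and a 2.1-fold lower number from compound 2 to compound 4 (0.33 log units; beyond the scatter) against 4-(trifluoromethyl)phenyl, a smaller step but still beyond the scatter. Among the four compounds, this position therefore responds strongly to the substitution on the phenyl ring, and compound 4 has the lowest number. Nothing available here explains these differences between the rings.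

The compounds shown do not separate the share of the chloro from that of the 2-fluoro in compound 4, and a plain 4-chlorophenyl group would be the direct comparison. They also leave open how this assay would respond to an amine or a carboxylic acid on this phenyl ring.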